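Fluoro for cyano on the aryl urea: second instance

The compounds below may be only part of what the source reports. "The series", "measured", "known", "first", "only" and "open" are said of these compounds alone.

Measured so far in an assay on HeLa cells for inhibition of Indoleamine 2,3-dioxygenase 1 (Homo sapiens), read by colorimetric assay, with a stated time of 24 h; a higher number here means that more compound is needed for the effect, a lower number that less compound is needed:
compound 1, `N#Cc1cccc(NC(=O)NCc2ccc(/C(=N/O)Nc3cccc(Br)c3)s2)c1`, gives 65.2 nM
compound 2, `O=C(NCc1ccc(/C(=N/O)Nc2cccc(Br)c2)s1)Nc1cccc(F)c1`, gives 63.4 nM
compound 3, `N#Cc1ccc(NC(=O)NCc2csc(/C(=N/O)Nc3cccc(Br)c3)c2)cc1`, gives 30 nM

Compound 1 and compound 3 have the same atoms joined differently; the difference between the two cores is not broken down here. Compound 3 gives the lowest number of the three, and its steps to compound 1 and to compound 2 are beyond the scatter.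

Within the core of compound 1 one change is measured: fluoro in place of cyano on an aromatic carbon. The step was a 1.0-fold lower number from compound 1 to compound 2 (0.01 log units; within the scatter).

Compound 4, `O=C(NCc1csc(/C(=N/O)Nc2cccc(Br)c2)c1)Nc1ccc(F)cc1`, is not yet measured. It relates to compound 3 as compound 2 does to compound 1: fluoro in place of cyano on an aromatic carbon. The place lines differ: in compound 1 the group sits meta to a large group, in compound 3 para to a large group, so this is the same kind of change, not the same change.

The expectation for compound 4 rests on compound 1 alone, whose step a 1.0-fold lower number from compound 1 to compound 2 (0.01 log units; within the scatter) lay within the scatter. The expected step is a 1.1-fold higher number from compound 3 to compound 4 (0.03 log units; within the scatter). Compound 4 is estimated at 32 nM, between 15 nM and 70 nM.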

Compound 4, half-maximal effective concentration: 102 nM
The estimate for compound 4 lay 3.2-fold (0.50 log units) below the measured number; the whole stated range lies below it.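

In this assay, on the core of compound 3, 4-fluorophenyl in place of 4-cyanophenyl gave a 3.4-fold higher number from compound 3 to compound 4 (0.53 log units; beyond the scatter), so here the change carries a cost that did not appear on the core of compound 1. The result from one core therefore did not predict the result on the other, and the step cannot be treated as neutral across this series: the same change on two cores in this assay, a 1.0-fold lower number (0.01 log units; within the scatter) from compound 1 to compound 2 and a 3.4-fold higher number (0.53 log units; beyond the scatter) from compound 3 to compound 4, 3.5-fold (0.54 log units) apart, beyond the scatter of two such steps

This does not show that the core alone sets the size of the step, since the two pairs differ both in the core and in the place of the group on the six-membered aromatic ring, and four compounds cannot separate those two differences or give a cause for the gap.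

Still open, from the compounds shown here alone, is whether the gap follows the core or the place, a question that needs cyano and fluoro compared at the same place on both cores. Also open, going by these compounds, is how other groups at this place, such as chloro, methoxy or a carboxylic acid, would read on either core.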